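The source may hold more compounds than are shown below. What is called first, only, known or untested is meant among the compounds shown, and "the series" means these compounds.

Measured in a physicochemical assay, read by spectrophotometry, with a stated time of 6 min; on this read-out lower numbers stand for stronger inhibition and higher numbers for weaker inhibition:

- compound 1 `O=C(CCc1nc2ccccc2c(=O)[nH]1)N/N=C/c1ccc(O)cc1` gives 105000000 nM
- compound 2 `COc1cc(/C=N/NC(=O)CCc2nc3ccccc3c(=O)[nH]2)cc(OC)c1OC` gives 55000000 nM
- compound 3 `O=C(CCc1nc2ccccc2c(=O)[nH]1)N/N=C/c1ccc(Cl)cc1` gives 185000000 nM

Compound 3 , at 185000000 nM, stands level with compound 1 , at 105000000 nM, and at a higher number than compound 2 , at 55000000 nM. The next compound, compound 4 `COc1ccc(/C=N/NC(=O)CCc2nc3ccccc3c(=O)[nH]2)cc1`, has not yet been measured. It replaces the group on compound 3 with methoxy in place of chloro on an aromatic carbon, para to a large group: methoxy in place of chloro on an aromatic carbon. Going by the values given here, no measured step makes this exact change. The nearest evidence is a 1.8-fold higher number from compound 1 to compound 3 (0.25 log units; within the scatter), a swap at the same place that stays within the scatter. Compound 2 also carries methoxy groups and reads 55000000 nM, but it differs from compound 4 in more than one place. Only a small move toward the lower numbers is therefore expected, and nothing clearly beyond the scatter. The expected change is a 1.9-fold lower number from compound 3 to compound 4 (0.27 log units; within the scatter). For compound 4 the estimated value is 100000000 nM, with an expected range of 50000000 nM to 200000000 nM.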

Compound 4, half-maximal inhibitory concentration: 75000000 nM
Beside the measured number, compound 4's estimate is 1.3-fold (0.12 log units) above it; the range from low to high includes it.
By their numbers in this assay, from the lowest: compounds 2, 4, 1 and 3 (each within the scatter of the next, the first and the last beyond it).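

In this assay, going by these compounds alone, the swap on the aromatic carbon para to a large group now gives a step beyond the scatter, though a modest one: a 2.5-fold lower number from compound 3 to compound 4 (0.39 log units; beyond the scatter), whereas the only earlier step at this place stayed within it. Capping the hydroxy oxygen with methyl does not separate the compounds, with a 1.4-fold lower number from compound 1 to compound 4 (0.15 log units; within the scatter), so compound 1 lies within the scatter of both compound 3 and compound 4, and only chloro and methoxy are told apart at this place. Nothing available explains why this change moves the number.

The compounds shown leave open how an amine or a carboxylic acid at this place would read. They also leave open whether a longer chain on the oxygen, such as ethoxy, would read differently from methoxy.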